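A few compounds are considered here, and "the series" means these few. Any claim that something is new, unique, unknown or untested is made for them only; others in the source may bear on it.

Measured in a functional assay on A549 cells (Homo sapiens) for antiproliferative activity, read by MTT assay, with a stated time of 72 h; a lower number here means a stronger inhibitor, a higher number a weaker inhibitor:

compound 1 `CC(C)(C)c1cn(C[C@H](O)[C@H]2OC(=O)C(OCc3ccccc3)=C2OCc2ccccc2)nn1` — 34000 nM
compound 3 `O=C1O[C@H]([C@@H](O)Cn2cc(-c3cc(F)cc(F)c3)nn2)C(OCc2ccccc2)=C1OCc1ccccc1` — 41200 nM
compound 2 `COc1ccc(-c2cn(C/C=C3\OC(=O)C(OCc4ccccc4)=C3OCc3ccccc3)nn2)cc1` — a limit of the assay, > 100000 nM, not a number

Compound 1 and compound 3 sit together: a 1.2-fold higher number from compound 1 to compound 3 (0.08 log units; within the scatter). Compound 2 gives only a limit in this assay; (the limit of > 100000 nM in this assay, at which 1 of the 3 values shown sits), so it adds nothing on size. Compound 1 thus stands with one neighbour within the scatter and one compound known only as a limit.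

The unmeasured compound 4 `C[Si](C)(C)c1cn(C[C@H](O)[C@H]2OC(=O)C(OCc3ccccc3)=C2OCc2ccccc2)nn1` differs from compound 1 in one place: a group of 4 heavy atoms (3 carbon, 1 silicon; no ring) in place of a group of 4 heavy atoms (4 carbon; no ring), on an aromatic carbon. For the measured compounds named here, no measured step changes this group for one of the same shape and size; the only step on the same carbon, from compound 1 to compound 3, swaps it for a ring and stays within the scatter. Nothing measured here points to a step beyond the scatter for compound 4, in either direction.

For compound 4 the expectation is therefore a number close to that of compound 1, estimated at 30000 nM, with a range of 12000 nM to 80000 nM. The step this estimate implies, a 1.1-fold lower number from compound 1 to compound 4 (0.05 log units; within the scatter), is expected to lie within the scatter.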

Compound 4, half-maximal inhibitory concentration: 19200 nM
Estimate against measurement, compound 4: 1.6-fold (0.19 log units) above, within the range that was stated.
By their numbers in this assay, from the lowest: compounds 4, 1 and 3 (each within the scatter of the next, the first and the last beyond it). At a limit, above all of these: compound 2.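

In this assay, the group of 3 carbon and 1 silicon in place of tert-butyl on this aromatic carbon gives a 1.8-fold lower number from compound 1 to compound 4 (0.25 log units; within the scatter), so a silicon-for-carbon exchange within a group of the same heavy-atom count does not shift the number beyond the scatter. For the compounds shown here, the same carbon now also gives the first step beyond the scatter: a 2.1-fold lower number from compound 3 to compound 4 (0.33 log units; beyond the scatter), although that step is modest and compound 4 and compound 3 differ by a whole aromatic ring against a group with no ring. Compound 1 stays within the scatter of both compound 3 and compound 4, so the three groups at this position separate only at their two ends, and only narrowly, which makes this carbon look permissive for the groups shown rather than a site of large changes.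

Open, on these data alone, is whether an amine, a carboxylic acid or a longer alkyl chain on this aromatic carbon would move the number further than these steps do. Nothing shown gives a reason for either step, and the one supporting note available, on a limit reached by another compound, does not bear on this result.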